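Aminomethyl in Place of Ethynyl on the Chain Carbon

A few compounds are considered here, and "the series" means these few. Any claim that something is new, unique, unknown or untested is made for them only; others in the source may bear on it.

Measured so far in an assay on isolated protein for inhibition of Thymidylate synthase (Mus musculus); on this read-out lower numbers stand for stronger inhibition and higher numbers for weaker inhibition:
compound 1 `Cc1nc2ccc(CN(CC(N)=O)c3ccc(C(=O)N[C@@H](CCC(=O)O)C(=O)O)c(F)c3)cc2c(=O)[nH]1` gives 1340 nM
compound 2 `Cc1nc2ccc(CN(C)c3ccc(C(=O)N[C@@H](CCC(=O)O)C(=O)O)c(F)c3)cc2c(=O)[nH]1` gives 120 nM
compound 3 `C#CCN(Cc1ccc2nc(C)[nH]c(=O)c2c1)c1ccc(C(=O)N[C@@H](CCC(=O)O)C(=O)O)c(F)c1` gives 20 nM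

Compound 3 stands lowest of the three, with compound 2 nearest at a 6.0-fold lower number from compound 2 to compound 3 (0.78 log units; beyond the scatter) and compound 1 furthest at a 67-fold lower number from compound 1 to compound 3 (1.83 log units; beyond the scatter). Compound 4 `Cc1nc2ccc(CN(CCN)c3ccc(C(=O)N[C@@H](CCC(=O)O)C(=O)O)c(F)c3)cc2c(=O)[nH]1` differs from compound 3 by aminomethyl in place of ethynyl on a saturated chain carbon bound to a nitrogen on an aromatic ring. Going by the values given here, the steps that bear on it are the two that end in compound 3: the step from carbamoyl, which like aminomethyl carries a donor and an acceptor, was a 67-fold lower number from compound 1 to compound 3 (1.83 log units; beyond the scatter), and the step from hydrogen was a 6.0-fold lower number from compound 2 to compound 3 (0.78 log units; beyond the scatter). Both point the same way, so compound 4 is expected to give a higher number in this assay, estimated as a 20-fold higher number from compound 3 to compound 4 (1.30 log units; beyond the scatter). Compound 4 is therefore estimated at 400 nM, within 100 nM to 1500 nM.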

Compound 4, half-maximal inhibitory concentration: 11700 nM
Beside the measured number, compound 4's estimate is 29-fold (1.47 log units) below it; the whole stated range lies below it.
By their numbers in this assay, from the lowest: compound 3; then compound 2; then compound 1; then compound 4.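

In this assay, aminomethyl on this chain carbon gives the highest number of the four: the change from ethynyl is a 590-fold higher number from compound 3 to compound 4 (2.77 log units; beyond the scatter) and the change from hydrogen is a 98-fold higher number from compound 2 to compound 4 (1.99 log units; beyond the scatter) so the change does more than lose what ethynyl gained. Carbamoyl and aminomethyl each carry a donor and an acceptor, yet they are not alike here, with an 8.7-fold higher number from compound 1 to compound 4 (0.94 log units; beyond the scatter) as the step between them. Sharing those counts therefore did not settle the number at this place. On these data alone, whether a longer chain ending in an amine, or a carboxylic acid on this carbon, would follow aminomethyl remains open. Nothing at hand accounts for the size of this rise.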